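Swapping the Outer Ring at the End of the Linker

The source may hold more compounds than are shown below. What is called first, only, known or untested is meant among the compounds shown, and "the series" means these compounds.

Three measured compounds share one core and differ only in the group attached on a triple-bonded carbon. Compound 1 `C#Cc1ccc2ncn(-c3ccnc(N)n3)c2c1` gives 251 nM in an assay on Sf9 cells for inhibition of mitogen-activated protein kinase kinase kinase 14 variant S549D (Homo sapiens), with a stated time of 30 min, in the presence of a further agent that is not named here; a lower number here means a stronger inhibitor, a higher number a weaker inhibitor. Compound 2 `C#Cc1cccc(C#Cc2ccc3ncn(-c4ccnc(N)n4)c3c2)n1` gives 3160 nM in this assay, and compound 3 `C#Cc1cncc(C#Cc2ccc3ncn(-c4ccnc(N)n4)c3c2)n1` gives 6310 nM, the highest of the three numbers shown, though its gap to compound 2 is within the scatter: the step is a 2.0-fold higher number from compound 2 to compound 3 (0.30 log units; within the scatter), whereas a 25-fold higher number from compound 1 to compound 3 (1.40 log units; beyond the scatter) is large. Compound 4 `C=Cc1ccc(C#Cc2ccc3ncn(-c4ccnc(N)n4)c3c2)cn1` differs from compound 3 by a group of 8 heavy atoms (7 carbon, 1 nitrogen; one six-membered aromatic ring with 1 hetero atom) in place of a group of 8 heavy atoms (6 carbon, 2 nitrogen; one six-membered aromatic ring with 2 hetero atoms), on a triple-bonded carbon. Going by the values given here, the only measured guide is the earlier exchange of ring types, a 2.0-fold higher number from compound 2 to compound 3 (0.30 log units; within the scatter), which stayed within the scatter, so the expected step is a 2.0-fold lower number from compound 3 to compound 4 (0.29 log units; within the scatter), modest and toward a lower number. Compound 4 is therefore estimated at 3200 nM, with a range from 1000 nM to 10000 nM.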

Compound 4, half-maximal inhibitory concentration: 79400 nM
Compound 4: the middle estimate sits 25-fold (1.39 log units) below what was measured, and the stated range ends below it.
By their numbers in this assay, from the lowest: compound 1; then compounds 2 and 3 (each within the scatter of the next); then compound 4.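

Placing 6-vinylpyridin-3-yl on the triple-bonded carbon gives a 13-fold higher number from compound 3 to compound 4 (1.10 log units; beyond the scatter) and a 25-fold higher number from compound 2 to compound 4 (1.40 log units; beyond the scatter) in this assay and thus shows that an outer ring with the same heavy-atom count can still move the number far beyond the scatter. The full change from the unextended compound amounts to a 320-fold higher number from compound 1 to compound 4 (2.50 log units; beyond the scatter) and is the largest step in this set. Nothing shown here explains this loss. From the compounds shown here alone, it remains open whether the vinyl group itself drives the step, and whether an ethyl group or an amine in its place would give a lower number.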